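Amide Replacement on a Dihydroxyphenyl Thiadiazole Scaffold

The compounds below may be only part of what the source reports. "The series", "measured", "known", "first", "only" and "open" are said of these compounds alone.

Measured compounds:
compound 1 `O=C(Nc1nnc(-c2ccc(O)c(O)c2)s1)c1ccc(Cl)cc1`: 47300 nM
compound 2 `O=C(Nc1nnc(-c2cccc(O)c2O)s1)c1ccc(Cl)cc1`: 13000 nM

Of the compounds shown here, two have been measured so far, both carrying a chlorinated benzamide on the shared core and differing only in how the hydroxy groups are set on the phenyl ring. In a functional assay on HeLa cells (Homo sapiens) for cytotoxicity, read by MTT assay, with a stated time of 72 h (on this read-out lower numbers stand for stronger inhibition and higher numbers for weaker inhibition), compound 1 gives 47300 nM, the highest of the two numbers recorded. Compound 2 gives 13000 nM, a lower number, and the gap between the two compounds lies beyond the usual scatter of this kind of measurement.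

Compound 3 `O=C(COc1ccccc1)Nc1nnc(-c2ccc(O)c(O)c2)s1` has not yet been measured. It differs from compound 1 by phenoxymethyl in place of 4-chlorophenyl on a carbonyl carbon. Within the data shown here, no measured pair shows this particular change, so there is nothing in the recorded numbers that points to a direction for it. The step from compound 1 to compound 3 in this assay is therefore expected to be small, likely none beyond the scatter, and is estimated as a 1.2-fold lower number from compound 1 to compound 3 (0.07 log units; within the scatter). On that basis compound 3 is expected to give about 40000 nM, with a range from 12000 nM to 130000 nM.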

Compound 3, half-maximal inhibitory concentration: 51300 nM
The estimate for compound 3 lay 1.3-fold (0.11 log units) below the measured number, and the stated range covers the measured number.
By their numbers in this assay, from the lowest: compound 2; then compounds 1 and 3 (each within the scatter of the next).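

In this assay, among these compounds, putting phenoxymethyl in place of 4-chlorophenyl on a carbonyl carbon gives a 1.1-fold higher number from compound 1 to compound 3 (0.04 log units; within the scatter) and is the first single change recorded at this position, since compound 1 and compound 2 differ only in how the hydroxy groups are set on the phenyl ring. The exchange removes the chlorine and brings in an oxygen that counts as a hydrogen-bond acceptor, yet the step stays within the scatter, so on the hydroxy pattern of compound 1 these two groups cannot be told apart in this read-out. No measurement on record accounts for this result. 

On these data alone, what remains open is whether a group of a different kind on the same carbonyl carbon, such as an aminomethyl group, a carboxylic acid or a longer alkyl chain, would shift the number beyond the scatter. As far as these compounds go, it is also open whether phenoxymethyl would give a similarly small step on the hydroxy pattern of compound 2, which carries the lower number so far.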